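Moving the Fluorine on the Carboxyphenyl Ether

This account rests on a few compounds, and the source may have more. Where it says the series, first, only, none or still open, it means among the compounds named here.

Compound 2 `Cc1c(OCCCCOc2ccc(C(=O)O)c(F)c2)ccc(C(=O)CC(C)(C)C)c1O` gives 1110 nM in an assay for positive allosteric modulation of metabotropic glutamate receptor 3 (Rattus norvegicus) (on this read-out higher numbers stand for an effect only at larger amounts of compound and lower numbers for an effect already at smaller amounts), the higher of the two numbers at hand; compound 1 `Cc1ncc(OCCCCOc2ccc(C(=O)CC(C)(C)C)c(O)c2C)cc1C(=O)O` gives 79 nM, and the step of a 14-fold higher number from compound 1 to compound 2 (1.15 log units; beyond the scatter) was large. Compound 3 `Cc1c(OCCCCOc2ccc(C(=O)O)cc2F)ccc(C(=O)CC(C)(C)C)c1O` differs from compound 2 only by 4-carboxy-2-fluorophenyl in place of 4-carboxy-3-fluorophenyl on an oxygen on a saturated carbon. Going by the values given here, no measured step bears on this rearrangement: the single recorded step exchanged the whole aryl group and says nothing about where the fluorine sits. The expected step is therefore a 1.1-fold lower number from compound 2 to compound 3 (0.05 log units; within the scatter), none beyond the scatter. Compound 3 is estimated at 1000 nM, within a range from 350 nM to 3000 nM.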

Compound 3, half-maximal effective concentration: 1230 nM
Beside the measured number, compound 3's estimate is 1.2-fold (0.09 log units) below it; the range from low to high includes it.
By their numbers in this assay, from the lowest: compound 1; then compounds 2 and 3 (each within the scatter of the next).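

In this assay, moving the fluorine gives a 1.1-fold higher number from compound 2 to compound 3 (0.04 log units; within the scatter), so on this ether 4-carboxy-2-fluorophenyl and 4-carboxy-3-fluorophenyl cannot be told apart. The distance from the 5-carboxy-6-methylpyridin-3-yl group remains with the new placement, at a 16-fold higher number from compound 1 to compound 3 (1.19 log units; beyond the scatter), so the large step seen before does not depend on which of these two fluorine placements is present. Nothing measured beyond these numbers accounts for either step.

From the compounds shown here alone, it remains open whether a plain 4-carboxyphenyl group, without fluorine, would fall with compound 2 and compound 3 or nearer compound 1. Going by these compounds, a 5-carboxypyridin-3-yl group lacking the methyl is equally open.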